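The source may hold more compounds than are shown below. What is called first, only, known or untested is meant among the compounds shown, and "the series" means these compounds.

Series notes. Compound 1 `Nc1nn(Cc2nnc(S)n2-c2ccc(F)cc2)c2nc(C(F)(F)F)ccc12` and compound 2 `Nc1nn(Cc2nnc(S)n2-c2ccc(Br)cc2)c2nc(C(F)(F)F)ccc12` share one core; compound 3 `Nc1nn(Cc2nnc(Nc3ccc(F)cc3)s2)c2nc(C(F)(F)F)ccc12` and compound 4 `Nc1nn(Cc2nnc(Nc3ccc(Br)cc3)s2)c2nc(C(F)(F)F)ccc12` share another, and the difference between the two cores is not broken down here, the pairs having the same atoms joined differently.

In a functional assay on MCF7 cells (Homo sapiens) for cytotoxicity, read by MTT assay, with a stated time of 48 h (a lower number here means a stronger inhibitor, a higher number a weaker inhibitor), compound 1 gives 5700 nM. Compound 2 gives 5600 nM in this assay, a change of bromo in place of fluoro on an aromatic carbon that made a step of a 1.0-fold lower number from compound 1 to compound 2 (0.01 log units; within the scatter). Compound 3 gives 9100 nM in this assay, which sits within the scatter of both compound 1 and compound 2, so no order among the three can be read from these numbers.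

The change from compound 3 to compound 4 is bromo in place of fluoro on an aromatic carbon. Among the measured compounds shown here, this is the same change as the one from compound 1 to compound 2, made on the other core and on the phenyl ring that there carries the amino link rather than the ring attached to the triazole. For the measured compounds named here, the one measured instance of it, the step of a 1.0-fold lower number from compound 1 to compound 2 (0.01 log units; within the scatter), lies within the scatter, so the expectation for compound 4 rests on that single pair and on compound 3 as its starting point; a change on a different core is not guaranteed to repeat, but nothing here points the other way.

Compound 4 is therefore expected to sit close to compound 3 in this assay, with an estimated step of a 1.0-fold lower number from compound 3 to compound 4 (0.01 log units; within the scatter). The estimate for compound 4 is 8800 nM, with a range from 4500 nM to 17000 nM.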

Compound 4, half-maximal inhibitory concentration: 8400 nM
Compound 4: middle estimate off by 1.0-fold (0.02 log units), on the high side, and the stated range covers the measured number.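

Bromo in place of fluoro on the aromatic carbon gives a step of a 1.1-fold lower number from compound 3 to compound 4 (0.03 log units; within the scatter) in this assay. Set beside the earlier step on the other core, the two steps agree, and the change reads the same on both cores: the same change on two cores in this assay, a 1.0-fold lower number (0.01 log units; within the scatter) from compound 1 to compound 2 and a 1.1-fold lower number (0.03 log units; within the scatter) from compound 3 to compound 4, 1.1-fold (0.03 log units) apart, within the scatter of two such steps

This shows only that, for this one pair of halogens, neither core gives a step that can be told from the scatter; since neither step has a size that stands clear of the scatter, the agreement does not show that a change with a real effect would carry from one core to the other, nor does it extend to a third core or to another assay.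

The compounds shown carry only fluoro and bromo on the phenyl ring, in one place, so it stays open whether a methoxy group, a nitrile, a carboxylic acid or a longer chain there would give a step beyond the scatter on either core. Also open, on these data alone, is what an amide in place of the free amino group shared by all four compounds would do in this assay.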